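The source may hold more compounds than are shown below. What is called first, only, known or untested is meant among the compounds shown, and "the series" means these compounds.

Series notes, carbamoyl benzoxazolone acid ceramidase inhibitors.

Compound 1 `O=C(NCCCCc1ccccc1)n1c(=O)oc2ccccc21` is the reference point. In an assay on HEK293 cells for inhibition of acid ceramidase (Homo sapiens), with a stated time of 10 min (on this read-out lower numbers stand for stronger inhibition and higher numbers for weaker inhibition), compound 1 gives 64 nM. Among the measured compounds shown here, compound 2 `O=C(NCCCc1ccccc1)n1c(=O)oc2ccccc21` is its only measured neighbour; in this assay compound 2 gives 55 nM. For the measured compounds named here, the one measured step, a 1.2-fold lower number from compound 1 to compound 2 (0.07 log units; within the scatter), concerns the chain, phenyl in place of benzyl on a saturated chain carbon three bonds along from the amide-type nitrogen. Compound 1 therefore stands with the higher of the two numbers, but the gap to compound 2 lies within the scatter, so the two cannot be ordered.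

Compound 3 `O=C(NCCCCc1ccccc1)n1c(=O)oc2cc(Br)ccc21` leaves the chain of compound 1 intact and alters the shared core: bromo in place of hydrogen on an aromatic carbon, with the chain untouched. Going by the values given here, no measured step touches the core, so nothing among the measured compounds speaks directly to this change; the chain step from compound 1 to compound 2 bears on it only in showing that small edits have so far stayed within the scatter.

For compound 3 no step beyond the scatter is expected, so the estimated step is a 1.3-fold lower number from compound 1 to compound 3 (0.11 log units; within the scatter). Compound 3 is expected to give 50 nM, with a range of 20 nM to 160 nM.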

Compound 3, half-maximal inhibitory concentration: 31 nM
Compound 3: middle estimate off by 1.6-fold (0.21 log units), on the high side; the measured number falls inside the stated range.
By their numbers in this assay, from the lowest: compounds 3, 2 and 1 (each within the scatter of the next, the first and the last beyond it).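

Bromo in place of hydrogen on an aromatic carbon, meta to a fused ring and para to a fused ring, gives a 2.1-fold lower number from compound 1 to compound 3 (0.31 log units; beyond the scatter) as a modest step and the only one shown that lies beyond the scatter. In this assay the shared core therefore responds to a single added bromine at this position, while the chain edit, a 1.2-fold lower number from compound 1 to compound 2 (0.07 log units; within the scatter), stays within the scatter, and the chain of compound 1 needs no change for the lower number to appear. No measurement shown gives a reason for the step on the core.

As far as these compounds go, whether the step belongs to bromine itself or would also appear with chloro, fluoro, methyl or methoxy on the same aromatic carbon remains open, as does the effect of bromo on the other aromatic carbons of that ring. Also open, from the compounds shown here alone, is whether bromo at this position would give a similar step on the shorter chain of compound 2, or with a longer chain or an amine in that chain.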